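Swapping bromo for hex-1-yn-1-yl on a shared core

This account rests on a few compounds, and the source may have more. Where it says the series, first, only, none or still open, it means among the compounds named here.

In a physicochemical assay for lipophilicity, at pH 7.4 (a higher number here means a more lipophilic compound, a lower number a more polar compound), compound 1 (`COc1ccc2[nH]c(C)c(Br)c(=O)c2c1`) gives 1.62. Among the compounds with values here, its only measured neighbour, compound 2 (`Cc1[nH]c2ccc(Br)cc2c(=O)c1Br`), gives 1.76, so the two stand within the scatter of each other. Within the data shown here, the one measured step, a number 0.14 log units higher from compound 1 to compound 2 (within the scatter), is bromo in place of methoxy on an aromatic carbon.

Compound 3 (`CCCCC#Cc1c(C)[nH]c2ccc(OC)cc2c1=O`) has yet to be measured. It shares the core of compound 1 and differs in one place: hex-1-yn-1-yl in place of bromo on an aromatic carbon. There, hex-1-yn-1-yl stands in place of bromo on an aromatic carbon, ortho to a methyl group.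

The measured step bears on this only loosely, since it concerns another place and another pair of groups. Among the measured compounds shown here, no measured step replaces bromo or brings in a chain, so the size must be judged from the change itself. Starting from compound 1 at 1.62, with a hex-1-yn-1-yl chain entering for bromo, a clear move to a higher number in this assay is expected, beyond the scatter. The expected step is a number 1.48 log units higher from compound 1 to compound 3 (beyond the scatter). For compound 3 the estimate is 3.1, within an expected range of 2.4 to 3.8.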

Compound 3, distribution coefficient: 5.25
Compound 3: middle estimate off by 2.15 log units, on the low side; the whole stated range lies below it.
By their numbers in this assay, from the lowest: compounds 1 and 2 (each within the scatter of the next); then compound 3.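

In this assay, this position is far from indifferent to the group it carries: hex-1-yn-1-yl in place of bromo on the aromatic carbon, ortho to a methyl group, gives a number 3.63 log units higher from compound 1 to compound 3 (beyond the scatter). The one earlier step, at another place and with another pair of groups, lay within the scatter, so this is the only step shown on the shared core that goes beyond it, and it shows that a single replacement can move this read-out by a large amount. The change brings in a chain of 6 heavy atoms with a triple bond outside aromatic rings where a single bromine stood, and nothing measured here accounts for the size of the step.

The compounds shown leave open whether the step follows the length of the chain or the triple bond, which a saturated hexyl chain, a shorter propynyl group or a chain ending in an amine at this place would help to separate. They also leave open whether the same replacement would give a step of similar size on the core of compound 2, which carries bromo in place of methoxy.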